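A few compounds are considered here, and "the series" means these few. Any claim that something is new, unique, unknown or untested is made for them only; others in the source may bear on it.

Three compounds share one core: a hydrazide carrying a tert-butyl group and two aromatic rings. In an assay on cells for agonist activity at ecdysone receptor (Bombyx mori), read by a luciferase reporter, with a stated time of 24 h (a lower number here means that less compound is needed, a higher number that more compound is needed for the effect), compound 1 `CC(C)(C)N(NC(=O)c1ccccc1)C(=O)c1ccccc1C(F)(F)F` gives 631 nM. Compound 2 `Cc1cc(C)cc(C(=O)N(NC(=O)c2ccccc2)C(C)(C)C)c1` gives 69.2 nM in this assay, and compound 3 `CC(C)(C)N(NC(=O)c1cccc(F)c1)C(=O)c1ccccc1Cl` gives 69.2 nM in this assay. Compound 3 thus stands level with compound 2, the two together giving the lowest numbers of the three, while compound 1 lies clearly beyond the scatter from both.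

Compound 4 `COc1cccc(C(=O)NN(C(=O)c2ccccc2Cl)C(C)(C)C)c1` differs from compound 3 in one place: methoxy in place of fluoro on an aromatic carbon, so a 3-fluorophenyl becomes a 3-methoxyphenyl. Among the compounds with values here, no measured pair shows this exchange, and the expected step is one that stays within the scatter, a 1.2-fold higher number from compound 3 to compound 4 (0.06 log units; within the scatter). Compound 4 is therefore estimated at 80 nM, with a range from 25 nM to 250 nM.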

Compound 4, half-maximal effective concentration: 52.5 nM
For compound 4 the middle estimate is 1.5-fold (0.18 log units) above the measured one; measured number inside the range.
By their numbers in this assay, from the lowest: compounds 4, 2 and 3 (each within the scatter of the next); then compound 1.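

Exchanging fluoro for methoxy on this aromatic carbon gives a 1.3-fold lower number from compound 3 to compound 4 (0.12 log units; within the scatter) in this assay. Within the data shown here, this is the first change that can be read at a single place, and it shows that two heavy atoms with a hydrogen-bond acceptor can replace one fluorine without a shift beyond the scatter. Nothing shown here explains why the two groups read alike.

Going by these compounds, it remains open whether an amine, a carboxylic acid or a longer chain such as ethoxy at this place would also stay within the scatter of compound 3. On these data alone, it is also open whether methoxy would read the same on the other aromatic ring.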